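The source may hold more compounds than are shown below. What is called first, only, known or untested is meant among the compounds shown, and "the series" means these compounds.

Compound 1 `CC[C@]1(c2cccc(N)c2)OC[C@H]([C@@H]2CCCCN2)O1`: 1230 nM
Compound 2 `CN1CCCC[C@H]1[C@H]1COC(c2ccccc2)(c2ccccc2)O1`: 4400 nM
Compound 3 `CCC[C@H](N)[C@H]1COC(c2ccccc2)(c2ccccc2)O1`: 3450 nM

All three numbers come from a functional assay (brain) for displacement of a labelled ligand, with Rattus norvegicus as the target; a lower number here means a stronger inhibitor, a higher number a weaker inhibitor. Compound 3 gives 3450 nM, the second highest of the three numbers; its nearest neighbour is compound 2 with 4400 nM, and the two lie within the scatter of each other, while compound 1 with 1230 nM sits a clear step lower.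

The unmeasured compound 4 `CCN[C@@H](C)[C@H]1COC(c2ccccc2)(c2ccccc2)O1` keeps the core of compound 3, and the change is 1-(ethylamino)ethyl in place of 1-aminobutyl on a saturated ring carbon. Going by the values given here, only one measured step touches the same saturated ring carbon: a 1.3-fold lower number from compound 2 to compound 3 (0.11 log units; within the scatter). That exchange of one group for another at this spot left the number essentially where it was. The step to compound 4 is of the same kind, and here the two groups even have the same atoms, joined differently, so no shift beyond the scatter is expected in this assay. Compound 4 is therefore estimated at 3200 nM, with a range from 1200 nM to 8500 nM. This expectation amounts to a step of a 1.1-fold lower number from compound 3 to compound 4 (0.03 log units; within the scatter).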

Compound 4, inhibition constant: 9000 nM
The estimate for compound 4 lay 2.8-fold (0.45 log units) below the measured number, and the stated range ends below it.
By their numbers in this assay, from the lowest: compound 1; then compounds 3 and 2 (each within the scatter of the next); then compound 4.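

In this assay, the group on this saturated ring carbon is not interchangeable: a 2.6-fold higher number from compound 3 to compound 4 (0.42 log units; beyond the scatter), even though 1-aminobutyl and 1-(ethylamino)ethyl have the same atoms, joined differently. Compared with the 1-methylpiperidin-2-yl group at the same spot, there is also a 2.0-fold higher number from compound 2 to compound 4 (0.31 log units; beyond the scatter), whereas the earlier exchange at this carbon stayed within the scatter. No measurement shown here accounts for these shifts, so their origin remains unknown.

The change from compound 3 to compound 4 moves the branch point of the chain and places an ethyl group on the nitrogen in a single step, leaving open which of the two matters. A 1-aminoethyl group or a 1-(dimethylamino)ethyl group on the same carbon would be informative here, and how either compares remains an open question.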